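From 3-fluorophenyl to 4-bromophenyl on a carbonyl carbon

This account rests on a few compounds, and the source may have more. Where it says the series, first, only, none or still open, it means among the compounds named here.

Values measured in a functional assay on HepG2 cells (Homo sapiens) for inhibition, read by MTT assay; on this read-out lower numbers stand for stronger inhibition and higher numbers for weaker inhibition:
Compound 1 `COc1cc2ncnc(Nc3ccc(NC(=O)c4ccccc4OC)cc3)c2cc1OC`: > 100000 nM.
Compound 2 `COc1cc2ncnc(Nc3ccc(NC(=O)c4cccc(F)c4)cc3)c2cc1OC`: 8200 nM.
Compound 3 `COc1cc2ncnc(Nc3ccc(NC(=O)c4cccc(Cl)c4)cc3)c2cc1OC`: 12000 nM.

For compound 1 the value > 100000 nM is a limit of the assay and not a number. That leaves two numbers in the series, and they lie within the scatter of each other: a 1.5-fold higher number from compound 2 to compound 3 (0.17 log units; within the scatter). Compound 2 therefore shares its standing with compound 3, and neither can be ranked over the other.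

The next compound, compound 4 `COc1cc2ncnc(Nc3ccc(NC(=O)c4ccc(Br)cc4)cc3)c2cc1OC`, has 4-bromophenyl in place of 3-fluorophenyl on a carbonyl carbon. The closest measured step is the swap of chloro for fluoro, a 1.5-fold higher number from compound 2 to compound 3 (0.17 log units; within the scatter), which stays within the scatter. Much larger steps came with leaving 2-methoxyphenyl: an at least 12-fold lower number from compound 1 to compound 2 (1.08 log units; beyond the scatter) and an at least 8.3-fold lower number from compound 1 to compound 3 (0.92 log units; beyond the scatter). Both of these start from a limit, and neither involves a bromo group. Among the compounds with values here, no measured step covers this exact change, so the expectation stays loose, and it rests mainly on the small step to compound 3. The estimated step in this assay is a 1.2-fold higher number from compound 2 to compound 4 (0.09 log units; within the scatter), which is no real change beyond the scatter. For compound 4 the expected value is 10000 nM, with an estimated range from 3000 nM to 35000 nM.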

Compound 4, half-maximal inhibitory concentration: 35000 nM
For compound 4 the middle estimate is 3.5-fold (0.54 log units) below the measured one; the range from low to high includes it.
By their numbers in this assay, from the lowest: compounds 2 and 3 (each within the scatter of the next); then compound 4. At a limit, above all of these: compound 1.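

In this assay, the swap on this carbonyl carbon now gives steps beyond the scatter, a 4.3-fold higher number from compound 2 to compound 4 (0.63 log units; beyond the scatter) and a 2.9-fold higher number from compound 3 to compound 4 (0.46 log units; beyond the scatter), whereas chloro in place of fluoro had separated nothing. Compound 4 therefore stands apart from compound 2 and compound 3, which stay level with each other, so the group on this carbonyl carbon can matter among halogen-bearing phenyl rings as well as on leaving 2-methoxyphenyl. The step away from 2-methoxyphenyl, an at least 2.8-fold lower number from compound 1 to compound 4 (0.45 log units; beyond the scatter), remains beyond the scatter, but it starts from a limit of the assay and not a number: the limit of > 100000 nM in this assay, at which 1 of the 4 values shown sits.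

The change to 4-bromophenyl alters both the halogen and its place on the ring, so the compounds shown cannot say which of the two goes with the higher number, and a 3-bromophenyl or a 4-fluorophenyl group on this carbonyl carbon would pull the two apart. From the compounds shown here alone, how a 4-aminophenyl or a 4-carboxyphenyl group would read at this position also remains open.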